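Replacing the amide substituent: from compound 3 to compound 4

This account rests on a few compounds, and the source may have more. Where it says the series, first, only, none or still open, it means among the compounds named here.

Compound 1 `CNC(=O)c1ccncc1Nc1cc(-c2ccc3ccn(C)c3c2)c2nccnc2c1`: 7020 nM
Compound 2 `Cn1cc(NC(=O)c2ccncc2Nc2cc(-c3ccc4ccn(C)c4c3)c3nccnc3c2)cn1`: 26500 nM
Compound 3 `CN1CC(NC(=O)c2ccncc2Nc2cc(-c3ccc4ccn(C)c4c3)c3nccnc3c2)CCC1=O`: 96500 nM

All three compounds share one core and differ only in the group carried on an amide-type nitrogen. In an assay on lysate for inhibition of 6-phosphofructo-2-kinase/fructose-2,6-bisphosphatase 3 (Homo sapiens), with stated times of 0.5 min and 45 min (on this read-out lower numbers stand for stronger inhibition and higher numbers for weaker inhibition), compound 3 gives the highest number of the three. The nearest is compound 2, as the step of a 3.6-fold higher number from compound 2 to compound 3 (0.56 log units; beyond the scatter) shows, and the furthest is compound 1, as the step of a 14-fold higher number from compound 1 to compound 3 (1.14 log units; beyond the scatter) shows.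

Compound 4 `CN1CCC(CNC(=O)c2ccncc2Nc2cc(-c3ccc4ccn(C)c4c3)c3nccnc3c2)C1` has not yet been measured. The change from compound 3 is (1-methylpyrrolidin-3-yl)methyl in place of 1-methyl-6-oxopiperidin-3-yl on an amide-type nitrogen. Among the measured compounds shown here, no measured pair shows this exact exchange. What the measured steps do show is that enlarging the group on this nitrogen beyond a methyl raised the number each time: a 3.8-fold higher number from compound 1 to compound 2 (0.58 log units; beyond the scatter) and a 14-fold higher number from compound 1 to compound 3 (1.14 log units; beyond the scatter). Compound 4 also carries a group much larger than a methyl, so a number clearly higher than that of compound 1 seems likely. Whether it lands above or below compound 3 cannot be told from the three compounds measured. On balance the expectation for compound 4 is 40000 nM, with a range from 10000 nM to 150000 nM, meaning an expected step of a 2.4-fold lower number from compound 3 to compound 4 (0.38 log units; beyond the scatter).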

Compound 4, half-maximal inhibitory concentration: 24000 nM
Beside the measured number, compound 4's estimate is 1.7-fold (0.22 log units) above it; measured number inside the range.
By their numbers in this assay, from the lowest: compound 1; then compounds 4 and 2 (each within the scatter of the next); then compound 3.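

In this assay, a large group on this amide-type nitrogen does not have to cost as much as the 1-methyl-6-oxopiperidin-3-yl group does: exchanging it for (1-methylpyrrolidin-3-yl)methyl recovers part of the loss (a 4.0-fold lower number from compound 3 to compound 4 (0.60 log units; beyond the scatter)). That new group and the 1-methyl-1H-pyrazol-4-yl group cannot be told apart here (a 1.1-fold lower number from compound 2 to compound 4 (0.04 log units; within the scatter)), even though one is a five-membered non-aromatic ring and the other is the pyrazole of compound 2, so these two quite different groups give the same result within the scatter. The methyl group of compound 1 still gives the lowest number, and the recovery does not reach it (a 3.4-fold higher number from compound 1 to compound 4 (0.53 log units; beyond the scatter)), so all three larger groups shown so far stand above the methyl.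

Nothing available bears on why these groups differ. From the compounds shown here alone, it remains open whether the plain amide, with hydrogen in place of the methyl, or an ethyl group would go below compound 1, and whether an open-chain dimethylaminoethyl group would match the ring-bearing group of compound 4.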